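The source may hold more compounds than are shown below. What is called first, only, known or untested is meant among the compounds shown, and "the series" means these compounds.

Compound 1 `COc1cccc(Nc2nccc(-c3ccncc3)n2)c1`: 400 nM
Compound 2 `Cc1cccc(Nc2nccc(-c3ccncc3)n2)c1`: 8800 nM
Compound 3 `CCc1cccc(Nc2nccc(-c3ccncc3)n2)c1`: 10600 nM

In a functional assay for inhibition, with Homo sapiens as the target (on this read-out higher numbers stand for weaker inhibition and lower numbers for stronger inhibition), compound 1 stands lowest of the three, and so is the strongest inhibitor here: a 22-fold higher number from compound 1 to compound 2 (1.34 log units; beyond the scatter) and a 27-fold higher number from compound 1 to compound 3 (1.42 log units; beyond the scatter), while compound 2 and compound 3 sit within the scatter of each other (a 1.2-fold higher number from compound 2 to compound 3 (0.08 log units; within the scatter)). Compound 4 `COc1cccc(Nc2nccc(-c3ccc(C)s3)n2)c1` keeps the methoxy group of compound 1 unchanged and instead alters the other ring on the shared core: 5-methylthiophen-2-yl in place of pyridin-4-yl on an aromatic carbon. Within the data shown here, none of the measured steps touches this part of the molecule; all three vary only the group on the other aromatic ring, so they offer no direct guide to this change. With that gap in the data, the estimate is broad, and a step toward a higher number, meaning weaker inhibition, is expected, a 3.8-fold higher number from compound 1 to compound 4 (0.57 log units; beyond the scatter). Compound 4 is therefore estimated at 1500 nM, within a range of 300 nM to 8000 nM.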

Compound 4, half-maximal inhibitory concentration: 2300 nM
Compound 4: the middle estimate sits 1.5-fold (0.19 log units) below what was measured; the measured number falls inside the stated range.
By their numbers in this assay, from the lowest: compound 1; then compound 4; then compounds 2 and 3 (each within the scatter of the next).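

Among these compounds, this is the first change to the other ring on the shared core: in this assay, 5-methylthiophen-2-yl in place of pyridin-4-yl gives a 5.8-fold higher number from compound 1 to compound 4 (0.76 log units; beyond the scatter) and so shows that this position affects the read-out. The count of heavy atoms and of hydrogen-bond acceptors stays the same across the swap, so these counts alone do not settle the outcome. No measurement here explains the shift.

Ring type and the added methyl changed together, so their separate shares remain open. A plain phenyl or an unsubstituted thiophen-2-yl at this position would help pull them apart.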